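The compounds below may be only part of what the source reports. "The series", "measured", "known", "first", "only" and "open" are said of these compounds alone.

Measured in a physicochemical assay for lipophilicity, measured as octanol-water partition; a lower number here means a more polar compound, a higher number a more lipophilic compound:
- compound 1 `COc1ccc2c(c1)[n+]([O-])c(C#N)c(-c1ccc(OC(F)(F)F)cc1)[n+]2[O-]`: 1.33
- compound 2 `N#Cc1c(-c2ccco2)[n+]([O-])c2ccccc2[n+]1[O-]`: 0.582

Of these two compounds, compound 2 stands lowest at 0.582, while compound 1 gives 1.33, a gap beyond the usual scatter. The two differ in more than one place, so that gap cannot be pinned on any single change.

Compound 3 `N#Cc1c(-c2ccco2)[n+]([O-])c2ccc(C(F)(F)F)cc2[n+]1[O-]` has not yet been measured in this assay. It is compound 2 with a single change: trifluoromethyl in place of hydrogen on an aromatic carbon. Going by the values given here, no measured pair shows this change on its own, so the expectation is a judgement and not a reading from the data. A rise beyond the scatter is expected, and the estimated size is a number 0.82 log units higher from compound 2 to compound 3 (beyond the scatter). The estimate for compound 3 is 1.4, with an expected range from 1 to 1.85.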

Compound 3, partition coefficient: 1.5
Compound 3: middle estimate off by 0.10 log units, on the low side; measured number inside the range.
By their numbers in this assay, from the lowest: compound 2; then compounds 1 and 3 (each within the scatter of the next).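

Going by these compounds alone, this is the first step here that isolates one change: in this assay, trifluoromethyl in place of hydrogen on an aromatic carbon gives a number 0.92 log units higher from compound 2 to compound 3 (beyond the scatter) with nothing else in the structure altered. A single substitution at this place on the six-membered aromatic ring of carbon only is therefore enough by itself to move the number beyond the usual scatter, which the gap between compound 1 and compound 2 could not show, since those two differ in more than one place. Nothing measured here accounts for the size of this step.

Within the data shown here, only one pair carries this change, so whether it acts the same way at another carbon of this ring or on another core stays open. On these data alone, how an amine or a carboxylic acid at this same place would shift the number also remains unknown.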